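Cyclopropyl in place of ethyl at the amide carbonyl

The compounds below may be only part of what the source reports. "The series", "measured", "known", "first", "only" and "open" are said of these compounds alone.

Compound 1 `CCC(=O)N1CCN(c2nc(-c3cnn(C)c3)ncc2C#N)C[C@H]1C`: < 16 mL/min/kg
Compound 2 `Cn1cc(-c2ncc(C#N)c(N3CCN(c4cccc(F)c4)C(C)(C)C3)n2)cn1`: 91 mL/min/kg

In an ADME assay on microsomes from liver (Homo sapiens) for pharmacokinetics (on this read-out lower numbers stand for slow clearance and higher numbers for fast clearance), compound 1 gives < 16 mL/min/kg, which is a limit of the assay and not a number. Compound 2 gives 91 mL/min/kg in this assay. Compound 3 `C[C@@H]1CN(c2nc(-c3cnn(C)c3)ncc2C#N)CCN1C(=O)C1CC1` differs from compound 1 by cyclopropyl in place of ethyl on a carbonyl carbon. The step that the limit leaves unreadable from compound 1 to compound 3 is expected to stay within the usual scatter, since compound 1 already sits at the limit of < 16 mL/min/kg in this assay, at which 1 of the 2 values shown sits, in this assay. Compound 3 is therefore estimated at 14 mL/min/kg in this assay, with a range from 6 mL/min/kg to 30 mL/min/kg, and the measurement may again return only a limit.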

Compound 3, clearance: 21 mL/min/kg
Estimate against measurement, compound 3: 1.5-fold (0.18 log units) below, within the range that was stated.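

With cyclopropyl in place of ethyl on a carbonyl carbon, this assay shows an at least 1.3-fold higher number from compound 1 to compound 3 (0.11 log units; that floor lies within the scatter). Compound 3 gives a number for this position, 21 mL/min/kg, so the three-membered ring can be placed on the value scale of this assay. The value of compound 1 is a limit, and the true size of the step stays unknown because only its floor can be read: the limit of < 16 mL/min/kg in this assay, at which 1 of the 3 values shown sits.

The compounds shown leave open how a longer chain such as butanoyl, or a chain carrying an amine, would read on this carbonyl carbon.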